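Removing a chain methyl from compound 1

The source may report more compounds than this note shows. Statements on the series, on what has been measured and on what is new or still open speak of the compounds shown alone.

Compound 1 (`CC(=O)N(C)C(C)C#CCn1ccnc1`) sits at the weak end of the three compounds measured in a functional assay on the whole organism for antagonist activity, with Mus musculus as the target; a higher number here means that more compound is needed for the effect, a lower number that less compound is needed. For compound 1 the assay gives only a limit, > 100 mg/kg, and not a number.

Two relatives carry an extra methyl on an aromatic carbon. Compound 2 (`CC(=O)N(C)C(C)C#CCn1cncc1C`) gives 3.7 mg/kg. Compound 3 (`CC(=O)N(C)C(C)C#CCn1ccnc1C`) gives 0.2 mg/kg. Both steps are large: an at least 27-fold lower number from compound 1 to compound 2 (1.43 log units; beyond the scatter), and an at least 500-fold lower number from compound 1 to compound 3 (2.69 log units; beyond the scatter).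

Compound 4 (`CC(=O)N(C)CC#CCn1ccnc1`) differs from compound 1 elsewhere: hydrogen in place of methyl on a saturated chain carbon bound to an amide-type nitrogen and a triple-bonded carbon. This is hydrogen in place of methyl on a saturated chain carbon bound to an amide-type nitrogen and a triple-bonded carbon. Among the compounds with values here, no measured step touches this place, so the two aromatic steps bear on it only indirectly. They show that a single methyl can shift the number a long way, which keeps the range wide, but they do not show what losing this methyl does. Compound 4 also lacks the aromatic methyl that separates compound 3 at 0.2 mg/kg from compound 1. No clear improvement is therefore expected in this assay, and the expected step, a number no higher from compound 1 to compound 4 (the limit leaves the size open), is none beyond the scatter. For compound 4 the estimated value is 100 mg/kg, with an expected range of 25 mg/kg to 400 mg/kg.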

Compound 4, dose for half-maximal effect: > 100 mg/kg
Compound 4 gave a limit, no number; the forecaster's own chance of this, stated with the estimate: 70%; the middle value sits exactly at the limit.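

In this assay, compound 1 and compound 4 both give only a limit and no number, so no step between them can be read: the limit of > 100 mg/kg in this assay, at which 2 of the 4 values shown sit.

The compounds shown leave open whether hydrogen in place of methyl on this saturated chain carbon changes the dose needed, with or without a methyl on an aromatic carbon.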